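Series notes: second nitro group on the aryl substituent

A few compounds are considered here, and "the series" means these few. Any claim that something is new, unique, unknown or untested is made for them only; others in the source may bear on it.

Two measured compounds share one core. Compound 1 `CCOC(=O)c1c(C)[nH]c(=O)c(C#N)c1-c1ccco1` and compound 2 `CCOC(=O)c1c(C)[nH]c(=O)c(C#N)c1-c1ccc([N+](=O)[O-])cc1` differ only in the aromatic ring attached to that core. In a functional assay on aorta (Rattus norvegicus) for inhibition (on this read-out lower numbers stand for smaller maximal responses and higher numbers for larger maximal responses), compound 1 reaches 100%, and compound 2 gives 98%. Compound 2 holds the lower of the two numbers, yet its distance to compound 1 lies within the scatter of repeated measurements, so the two cannot be ranked against each other on the present data. Among the compounds with values here, no step between measured compounds is established from which the effect of a further change could be read. Compound 3 `CCOC(=O)c1c(C)[nH]c(=O)c(C#N)c1-c1ccc([N+](=O)[O-])cc1[N+](=O)[O-]` is not yet measured; it differs from compound 2 by nitro in place of hydrogen on an aromatic carbon. With both measured values close to the full response of the read-out, no step beyond the scatter is expected in this assay, and the expected change is a number 3 percentage points lower from compound 2 to compound 3 (within the scatter). Compound 3 is estimated at 95%, with a range from 80% to 100%.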

Compound 3, largest response reached (reported as efficacy), in percent of the reference or control that the assay uses: 97%
The estimate for compound 3 lay 2 percentage points below the measured number; measured number inside the range.
By their numbers in this assay, from the lowest: compounds 3, 2 and 1 (each within the scatter of the next).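

Nitro in place of hydrogen, ortho to a large group and meta to a nitro group, provides the first one-place step in the series: a number 1 percentage points lower from compound 2 to compound 3 (within the scatter) in this assay. This position on the six-membered aromatic ring therefore carries a second nitro group, with its 3 heavy atoms, without a step beyond the scatter, and the read-out does not separate the two compounds. No measurement of another kind bears on this result, so the step stands without an explanation.

From the compounds shown here alone, it remains open whether an amine or a carboxylic acid in place of this second nitro group would give a step beyond the scatter in this assay. Also open, going by these compounds, is whether the same exchange of hydrogen for nitro on another carbon of the ring would leave the maximal response within the scatter.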